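The source may hold more compounds than are shown below. What is called first, only, known or untested is meant among the compounds shown, and "the series" means these compounds.

Measured so far in a functional assay on HUVEC cells (Homo sapiens) for inhibition; a lower number here means a stronger inhibitor, a higher number a weaker inhibitor

compound 1 `CN(c1ccc(NC(=O)Oc2ccccc2)cc1)c1ccnc(Nc2cccc(CS(C)(=O)=O)c2)n1` gives 224 nM
compound 2 `CN(c1ccc(N/C(S)=N/c2ccccc2)cc1)c1ccnc(Nc2cccc(CS(C)(=O)=O)c2)n1` gives 6 nM
compound 3 `CCNC(=O)Nc1ccc(N(C)c2ccnc(Nc3cccc(CS(C)(=O)=O)c3)n2)cc1` gives 3 nM

Compound 3 sits at the low end of these numbers, level with compound 2 within the scatter. Compound 4 `CN(C)CCNC(=O)Nc1ccc(N(C)c2ccnc(Nc3cccc(CS(C)(=O)=O)c3)n2)cc1` turns its ethylamino group into (2-(dimethylamino)ethyl)amino, which is dimethylamino in place of hydrogen on a saturated chain carbon, two bonds along the chain from an amide-type nitrogen. Among the measured compounds shown here, two measured steps bear on this part of the molecule. The change from phenoxy to ethylamino gives a 75-fold lower number from compound 1 to compound 3 (1.87 log units; beyond the scatter), a large step, while a 2.0-fold lower number from compound 2 to compound 3 (0.30 log units; within the scatter) stays within the scatter. Neither step tests a substituent on the ethyl chain, so the size of the new step remains uncertain. Nothing beyond the scatter is expected in this assay, with the expected change being a 1.3-fold higher number from compound 3 to compound 4 (0.12 log units; within the scatter). For compound 4 the estimated value is 4 nM, within an expected range of 1.5 nM to 15 nM.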

Compound 4, half-maximal inhibitory concentration: 530 nM
Estimate against measurement, compound 4: 130-fold (2.12 log units) below; the measured number lies above the stated range.
By their numbers in this assay, from the lowest: compounds 3 and 2 (each within the scatter of the next); then compound 1; then compound 4.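

In this assay, dimethylamino on a saturated chain carbon, two bonds along the chain from an amide-type nitrogen, costs a large loss (a 180-fold higher number from compound 3 to compound 4 (2.25 log units; beyond the scatter)), so this end of the ethylamino group does not accept every substituent. The loss also holds against the larger group of the thiol-bearing analogue (an 88-fold higher number from compound 2 to compound 4 (1.95 log units; beyond the scatter)) and, more modestly, against phenoxy (a 2.4-fold higher number from compound 1 to compound 4 (0.37 log units; beyond the scatter)). The compounds shown leave open whether the loss follows the amine itself or any substituent here, as a hydroxyl, a methoxy or a plain propyl chain could tell. Nothing available explains the loss.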